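The source may report more compounds than this note shows. Statements on the series, on what has been measured and on what is new or still open speak of the compounds shown alone.

Values in a functional assay on HepG2 cells (Homo sapiens) for cytotoxicity, read by sulforhodamine B assay, with a stated time of 24 h (a higher number here means a weaker inhibitor, a lower number a stronger inhibitor), so far

Compound 1 `Cc1ccc(/N=C2\C(=O)Nc3ccc(S(=O)(=O)N4CCOCC4)cc32)cc1` gives 12800 nM
Compound 2 `N/N=C1\C(=O)Nc2ccc(S(=O)(=O)N3CCOCC3)cc21` gives 32400 nM
Compound 3 `O=C1Nc2ccc(S(=O)(=O)N3CCOCC3)cc2/C1=N/c1ccc(C(=O)O)cc1` gives 23100 nM

Compound 3 at 23100 nM holds the middle number of the three, yet both steps that reach it (a 1.4-fold lower number from compound 2 to compound 3 (0.15 log units; within the scatter) and a 1.8-fold higher number from compound 1 to compound 3 (0.26 log units; within the scatter)) stay within the scatter. Among the compounds with values here, only one measured step (a 2.5-fold higher number from compound 1 to compound 2 (0.40 log units; beyond the scatter)) goes beyond the scatter, and only modestly.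

Compound 4 `O=C1Nc2ccc(S(=O)(=O)N3CCOCC3)cc2/C1=N/c1ccc(Cl)cc1` differs from compound 3 in one place, with chloro in place of carboxy on an aromatic carbon, para to a large group (chloro in place of carboxy on an aromatic carbon). Within the data shown here, no measured compound carries chloro, so the closest guide is the step that put carboxy in place of methyl on that carbon (a 1.8-fold higher number from compound 1 to compound 3 (0.26 log units; within the scatter)). Treating methyl as a stand-in for chloro is an assumption that these data cannot test. On that assumption, removing carboxy should give a lower number by a similar amount, a small change that would probably not clear the scatter. The expected step is a 1.8-fold lower number from compound 3 to compound 4 (0.25 log units; within the scatter) and it remains an estimate. For compound 4 the estimated value is 13000 nM with an expected range of 6000 nM to 26000 nM around it.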

Compound 4, half-maximal inhibitory concentration: 11800 nM
Beside the measured number, compound 4's estimate is 1.1-fold (0.04 log units) above it; the range from low to high includes it.
By their numbers in this assay, from the lowest: compounds 4, 1, 3 and 2 (each within the scatter of the next, the first and the last beyond it).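

In this assay the chloro group on this aromatic carbon, para to a large group, gives a 1.1-fold lower number from compound 1 to compound 4 (0.04 log units; within the scatter) and so cannot be told apart from methyl, while replacing carboxy gives a 2.0-fold lower number from compound 3 to compound 4 (0.29 log units; within the scatter) and also stays within the scatter. With chloro, methyl and carboxy all within the scatter of one another, this place has so far shown no measurable preference among the three groups. The new compound also adds a second step beyond the scatter, a 2.7-fold lower number from compound 2 to compound 4 (0.44 log units; beyond the scatter) for 4-chlorophenyl in place of amino on the double-bonded nitrogen, which is again modest and again involves compound 2, although compound 3 goes against any simple rule that an aromatic group beats amino there, as its step from compound 2 stays within the scatter. No measurement here offers an explanation for these numbers.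

Going by these compounds, what a fluoro group, a methoxy group or an amine on this same aromatic carbon would give remains open. So does the question of whether a longer chain in place of amino on the double-bonded nitrogen would sit closer to compound 2 or to compound 4.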